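Adding a bromo group to an inactive compound

A few compounds are considered here, and "the series" means these few. Any claim that something is new, unique, unknown or untested is made for them only; others in the source may bear on it.

Compound 1 `NS(=O)(=O)c1cccc(/N=C2\NC(=O)/C(=C3/C(=O)Nc4ccccc43)S2)c1`: > 200000 nM, a limit
Compound 2 `NS(=O)(=O)c1ccc(/N=C2\NC(=O)/C(=C3/C(=O)N(Cc4ccccc4)c4ccc(Br)cc43)S2)cc1`: > 200000 nM, a limit

Compound 1 has no exact number in a functional assay on MCF7 cells (Homo sapiens) for antiproliferative activity, read by MTT assay (a lower number here means a stronger inhibitor, a higher number a weaker inhibitor), where it stands at the limit of > 200000 nM in this assay, at which 2 of the 2 values shown sit. That reading is a limit of the assay and not a measured potency. Compound 2 gives a limit too, with > 200000 nM as its reading.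

Compound 3 `NS(=O)(=O)c1cccc(/N=C2\NC(=O)/C(=C3/C(=O)Nc4ccc(Br)cc43)S2)c1` keeps the core of compound 1 and has bromo in place of hydrogen on an aromatic carbon. Among the measured compounds shown here, no measured pair shows this change on its own, so its size in this assay is uncertain. Any change is expected to be modest and towards a lower number, and compound 3 may well stay at the limit. The expected step is an at least 1.6-fold lower number from compound 1 to compound 3 (0.22 log units; that floor lies within the scatter). The estimate for compound 3 is 120000 nM, with a range of 30000 nM to 200000 nM.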

Compound 3, half-maximal inhibitory concentration: > 200000 nM
Compound 3 gave a limit, no number; the forecaster's own chance of this, stated with the estimate: 55%; at least 1.6-fold (0.22 log units) between middle value and limit.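

Compound 3 and compound 1 both give only a limit in this assay, so the step between compound 1 and compound 3 cannot be read: the limit of > 200000 nM in this assay, at which 3 of the 3 values shown sit.

The compounds shown leave open what exact potency any of them has in this assay, and whether bromo in place of hydrogen changes it at all.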